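Swapping Furan for a Methylsulfanylphenyl Hydrazone Arm

This account rests on a few compounds, and the source may have more. Where it says the series, first, only, none or still open, it means among the compounds named here.

Of the compounds shown here, two on a shared core have been measured in a functional assay on HCT-116 cells (Homo sapiens) for antiproliferative activity, read by MTT assay; on this read-out higher numbers stand for weaker inhibition and lower numbers for stronger inhibition. Compound 1 `Cn1c(=O)c(=O)n(C2CCCC2)c2nc(N/N=C/c3cc(C(F)(F)F)c(O)c(C(F)(F)F)c3)ncc21` carries a phenyl ring bearing two trifluoromethyl groups and a hydroxyl on its hydrazone arm, and in this assay compound 1 gives 27100 nM. Compound 2 `Cn1c(=O)c(=O)n(C2CCCC2)c2nc(N/N=C/c3ccco3)ncc21` carries a furan-2-yl ring in the same position, and in this assay compound 2 gives 78700 nM, the higher of the two numbers; the gap between compound 2 and compound 1 lies beyond the usual scatter, so compound 2 is the weaker of the two on the numbers shown.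

Compound 3 `CSc1ccc(/C=N/Nc2ncc3c(n2)n(C2CCCC2)c(=O)c(=O)n3C)cc1` has not yet been measured. It differs from compound 2 in one place: 4-(methylsulfanyl)phenyl in place of furan-2-yl on a carbon with a double bond to nitrogen. Compound 1 is the only measured case of a six-membered aromatic ring of carbon only in this position, and its number is lower than that of compound 2. On that single comparison the step from compound 2 to compound 3 is expected to be a moderate one toward a lower number, a 2.5-fold lower number from compound 2 to compound 3 (0.39 log units; beyond the scatter). Compound 3 is therefore estimated at 32000 nM, within a range of 11000 nM to 95000 nM.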

Compound 3, half-maximal inhibitory concentration: 9010 nM
The estimate for compound 3 lay 3.6-fold (0.55 log units) above the measured number; the measured number lies below the stated range.
By their numbers in this assay, from the lowest: compound 3; then compound 1; then compound 2.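

In this assay, replacing furan-2-yl with 4-(methylsulfanyl)phenyl on the carbon with a double bond to nitrogen gives an 8.7-fold lower number from compound 2 to compound 3 (0.94 log units; beyond the scatter), a clear step beyond the scatter at a position where no single change had yet been read. Compound 1 had been the only case of a six-membered aromatic ring of carbon only here, and compound 3 now gives a second such case: both compound 1 at 27100 nM and compound 3 at 9010 nM stand lower than compound 2, and compound 3 has the lowest number of the three, so the low end of this series does not depend on the trifluoromethyl and hydroxyl groups of compound 1. No measurement presented here accounts for the size of this step.

The compounds shown leave open how much of the step belongs to the six-membered ring itself and how much to the methylsulfanyl group, as the two enter together. A plain phenyl ring, or a methoxy group or an amine in place of the methylsulfanyl group, would separate the two contributions.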